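The source may report more compounds than this note shows. Statements on the series, on what has been measured and on what is new or still open speak of the compounds shown alone.

Measured compounds in a functional assay on MCF7 cells (Homo sapiens) for antiproliferative activity, read by MTT assay, with a stated time of 72 h; a lower number here means a stronger inhibitor, a higher number a weaker inhibitor:
- compound 1, `CC1=CCC2C(CC[C@@]2(C)O)C(C)(C)C1CC[C@@H]1[C@@]2(C)CC[C@@H](O)C(C)(C)O[C@@H]2CC[C@]1(C)O`: 44500 nM
- compound 2, `CC(=O)O[C@H]1CC[C@]2(C)[C@H](CC[C@@](C)(O)[C@H]2CC[C@@H]2C(C)=CC[C@H]3[C@H](CC[C@]3(C)OC(C)=O)C2(C)C)OC1(C)C`: 39200 nM
- compound 3, `CC1=CC[C@H]2[C@H](CC[C@]2(C)O)C(C)(C)[C@@H]1CC[C@H]1[C@]2(C)CC[C@H](OC(=O)NCc3ccccc3)C(C)(C)O[C@H]2CC[C@@]1(C)O`: 24500 nM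

All three compounds share one core and differ only in the group carried on the oxygen of the pyran ring. Compound 3 gives the lowest of the three numbers, yet its gaps to compound 2 and to compound 1 both lie within the scatter of this assay, so the three cannot be placed in any order of strength, and none of them can be called the most or least active.

Compound 4, `CC1=CC[C@H]2[C@H](CC[C@]2(C)O)C(C)(C)[C@@H]1CC[C@H]1[C@]2(C)CC[C@H](OC(=O)c3ccccc3[N+](=O)[O-])C(C)(C)O[C@H]2CC[C@@]1(C)O`, is the next member. It differs from compound 3 by 2-nitrophenyl in place of benzylamino on a carbonyl carbon. Within the data shown here, no pair among the measured compounds shows this same change, so there is no measured step to lean on; the three measured values merely show that varying this position has so far moved nothing beyond the scatter.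

Compound 4 is therefore expected to land near 25000 nM, between 10000 nM and 60000 nM. The expected step, a 1.0-fold higher number from compound 3 to compound 4 (0.01 log units; within the scatter), is estimated to stay within the scatter, in no clear direction.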

Compound 4, half-maximal inhibitory concentration: 5200 nM
For compound 4 the middle estimate is 4.8-fold (0.68 log units) above the measured one; measured number below the stated range.
By their numbers in this assay, from the lowest: compound 4; then compounds 3, 2 and 1 (each within the scatter of the next).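

Among the earlier compounds, no change at this position in this assay moved the number beyond the scatter, so the position could have seemed indifferent to what it carries. Placing 2-nitrophenyl instead of benzylamino on the carbonyl carbon gives a 4.7-fold lower number from compound 3 to compound 4 (0.67 log units; beyond the scatter), a modest step but a real one, which shows that the position does respond to the group it holds. The aromatic ring stays through this change, while the hydrogen-bond donor of benzylamino leaves and the hydrogen-bond acceptors of 2-nitrophenyl enter, and nothing available explains the step or assigns it to any one of these differences.

On these data alone, it remains open whether a plain phenyl group would give a similar number in this assay. Also open, as far as these compounds go, is how an amine or a nitrile in place of the nitro group would fare.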